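Dichloromethylphenyl variant of compound 1 in the agonist assay

The compounds below may be only part of what the source reports. "The series", "measured", "known", "first", "only" and "open" are said of these compounds alone.

Compound 1 `Cc1cc(=O)oc2cc(OCc3nc(N)nc(Nc4ccc(F)cc4)n3)ccc12` gives the highest of the three numbers in an assay on COS-7 cells for agonist activity at Free fatty acid receptor 1 (Homo sapiens), read by scintillation counting and inositol phosphate accumulation, with a stated time of 90 min (a higher number here means that more compound is needed for the effect, a lower number that less compound is needed), at 18300 nM. Compound 2 `Cc1cc(=O)oc2cc(OCc3nc(N)nc(Nc4cccc(Cl)c4)n3)ccc12` gives 1110 nM in this assay, and compound 3 `Cc1cc(Nc2nc(N)nc(COc3ccc4c(C)cc(=O)oc4c3)n2)ccc1Cl` gives 240 nM. The step of a 16-fold lower number from compound 1 to compound 2 (1.22 log units; beyond the scatter) was large, and a 76-fold lower number from compound 1 to compound 3 (1.88 log units; beyond the scatter) was larger still, while a 4.6-fold lower number from compound 2 to compound 3 (0.67 log units; beyond the scatter) was modest. Compound 4 `Cc1c(Cl)cc(Nc2nc(N)nc(COc3ccc4c(C)cc(=O)oc4c3)n2)cc1Cl` differs from compound 1 in the following way: 3,5-dichloro-4-methylphenyl in place of 4-fluorophenyl on a nitrogen on an aromatic ring. Both measured steps away from compound 1 on this nitrogen went to lower numbers, and the more substituted ring of compound 3 went furthest, so a large step downward is expected here as well, a 73-fold lower number from compound 1 to compound 4 (1.86 log units; beyond the scatter). Compound 4 is therefore estimated at 250 nM in this assay, within a range of 50 nM to 1500 nM.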

Compound 4, half-maximal effective concentration: 600 nM
Compound 4: middle estimate off by 2.4-fold (0.38 log units), on the low side, within the range that was stated.
By their numbers in this assay, from the lowest: compound 3; then compounds 4 and 2 (each within the scatter of the next); then compound 1.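

In this assay the 3,5-dichloro-4-methylphenyl ring still gives a 31-fold lower number from compound 1 to compound 4 (1.48 log units; beyond the scatter) as a large step, yet more substitution on this ring does not by itself lower the number, for the change from the 4-chloro-3-methylphenyl ring gives a 2.5-fold higher number from compound 3 to compound 4 (0.40 log units; beyond the scatter) as a modest step. Set against the 3-chlorophenyl ring, it gives a 1.9-fold lower number from compound 2 to compound 4 (0.27 log units; within the scatter) and so cannot be ranked apart from it. Nothing available explains these differences. On these data alone, whether a methoxy group, an amine or a carboxylic acid on this phenyl ring would fall near compound 3 stays open.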